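The source may report more compounds than this note shows. Statements on the series, on what has been measured and on what is new or still open speak of the compounds shown alone.

In an assay on HEK293 cells for positive allosteric modulation of metabotropic glutamate receptor 2 (Rattus norvegicus), read by thallium flux, with a stated time of 2.5 min (on this read-out lower numbers stand for smaller maximal responses and higher numbers for larger maximal responses), compound 1 `Cc1c(OCCCCOc2ccc(C(=O)O)cc2)ccc(C(=O)CC(C)C)c1C` gives 19%, compound 2 `Cc1c(OCCCCOc2ccc(C(=O)O)c(Cl)c2)ccc(C(=O)CC(C)C)c1C` gives 33.1%, and compound 3 `Cc1c(OCCCCOc2ccc(C(=O)O)c(Cl)c2)ccc(C(=O)CC2CCCC2)c1C` gives 61.8%. Compound 2 therefore stands second highest of the three: the step of a number 14.1 percentage points higher from compound 1 to compound 2 (beyond the scatter) lies beyond the scatter, as does the larger step of a number 28.7 percentage points higher from compound 2 to compound 3 (beyond the scatter).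

Compound 4 `COC(=O)c1ccc(OCCCCOc2ccc(C(=O)CC(C)C)c(C)c2C)cc1` has not yet been measured in this assay. It differs from compound 2 in one place: 4-(methoxycarbonyl)phenyl in place of 4-carboxy-3-chlorophenyl on an oxygen on a saturated carbon. The group that leaves carries a chlorine and one hydrogen-bond donor; the group that enters carries no chlorine, no hydrogen-bond donor and two hydrogen-bond acceptors.

Among the compounds with values here, only one measured step bears on this change, and only partly. The step of a number 14.1 percentage points higher from compound 1 to compound 2 (beyond the scatter) shows what adding the chlorine did; compound 4, like compound 1, lacks that chlorine, so walking that step backwards points toward a modest fall. Within the data shown here, for the exchange of the carboxylic acid for the methyl ester no measured pair exists, so its contribution is unknown and widens the range.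

Compound 4 is therefore expected to give about 16% in this assay, within a range from 5% to 35%. That estimate means a step of a number 17.1 percentage points lower from compound 2 to compound 4 (beyond the scatter), a modest fall beyond the scatter.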

Compound 4, largest response reached (reported as percent of maximum), in percent of the reference or control that the assay uses: 15.9%
Compound 4: the middle estimate sits 0.1 percentage points above what was measured; low and high end bracket the measured number.
By their numbers in this assay, from the lowest: compounds 4 and 1 (each within the scatter of the next); then compound 2; then compound 3.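

Exchanging the carboxylic acid for its methyl ester, with no chlorine present in either compound, gives no readable change in this assay: a number 3.1 percentage points lower from compound 1 to compound 4 (within the scatter). Within the data shown here, this is the first measured pair that isolates the acid-to-ester exchange, and in this chlorine-free setting the acid hydrogen can be replaced by methyl without the maximal response moving beyond the scatter. The larger step, a number 17.2 percentage points lower from compound 2 to compound 4 (beyond the scatter), exchanges 4-carboxy-3-chlorophenyl for 4-(methoxycarbonyl)phenyl and so removes the chlorine and makes the ester together, but compound 1, which keeps the acid and lacks the chlorine, stands within the scatter of compound 4, so this fall need not be credited to the ester; no measurement here explains why the response behaves this way.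

Among these compounds, whether the ester would be tolerated as well alongside the chlorine, or alongside the cyclopentyl group of compound 3, remains open, as the effect of the exchange has been read only in the one chlorine-free pair. Also open, on these data alone, is how other replacements for the carboxylic acid, such as a primary amide or a tetrazole, or a bromine or fluorine in place of the chlorine, would compare.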